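Triazole nitrogen substituents in a flavanone-type series

The compounds below may be only part of what the source reports. "The series", "measured", "known", "first", "only" and "open" are said of these compounds alone.

Values in a functional assay on RAW264.7 cells (Mus musculus) for inhibition, read by Griess assay, with stated times of 2 h and 24 h; a lower number here means a stronger inhibitor, a higher number a weaker inhibitor:
compound 1, `COc1ccc([C@@H]2C/C(=N\O)c3c(O)cc(OCc4cn(CC5CC5)nn4)cc3O2)cc1O`: 6320 nM
compound 2, `COc1ccc([C@@H]2CC(=O)c3c(O)cc(OCc4cn(Cc5ccc(F)cc5)nn4)cc3O2)cc1O`: 15100 nM

Compound 2 has the higher of the two numbers, and its gap to compound 1 lies beyond the usual scatter. The two compounds differ in more than one place, so no single structural step can be read from this pair.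

Compound 3, `COc1ccc([C@@H]2CC(=O)c3c(O)cc(OCc4cn(C5CCCCC5)nn4)cc3O2)cc1O`, differs from compound 2 in one place: cyclohexyl in place of 4-fluorobenzyl on an aromatic nitrogen. Within the data shown here, no measured pair shows this exchange, and the two values available give no direction for it. The step from compound 2 to compound 3 is therefore expected to be small, not clearly beyond the scatter, with a slight lean toward a lower number: a 1.4-fold lower number from compound 2 to compound 3 (0.14 log units; within the scatter). Among the measured compounds shown here, compound 3 is estimated at 11000 nM, with a range from 3500 nM to 35000 nM, the width reflecting that only two compounds are known and neither shares the incoming group.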

Compound 3, half-maximal inhibitory concentration: 15600 nM
Compound 3: the middle estimate sits 1.4-fold (0.15 log units) below what was measured, and the stated range covers the measured number.
By their numbers in this assay, from the lowest: compound 1; then compounds 2 and 3 (each within the scatter of the next).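

In this assay, the exchange of 4-fluorobenzyl for cyclohexyl on the aromatic nitrogen gives a 1.0-fold higher number from compound 2 to compound 3 (0.01 log units; within the scatter), the only single-place step among the compounds shown, and it lies within the scatter. At this position on the shared core, the two carbon-only six-membered rings, one aromatic and one non-aromatic, are therefore not told apart by this read-out, and the loss of the fluorine-bearing benzyl group brings no measurable shift. No available evidence bears on why the two groups read alike.

As far as these compounds go, how an amine, a carboxylic acid or a longer alkyl chain on this nitrogen would read remains open. Compound 1 carries both an oxime and a cyclopropylmethyl group, and no compound shown separates the two.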